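This account rests on a few compounds, and the source may have more. Where it says the series, first, only, none or still open, it means among the compounds named here.

Working notes on the series:

- compound 1 `CCSC(=S)SCC(=O)c1ccccc1` gives 5010 nM
- compound 2 `[C-]#[N+]c1ccc(C(=O)CSC(=S)SCC)cc1` gives 7940 nM
- compound 3 `COc1ccc(C(=O)CS)cc1` gives 20000 nM
- compound 4 `CCSC(=S)SCC(=O)c1ccc(S(N)(=O)=O)cc1` is not yet measured

All values come from a functional assay on HeLa cells (Homo sapiens) for antiproliferative activity, read by resazurin assay; a higher number here means a weaker inhibitor, a lower number a stronger inhibitor. Compound 2 stands level with compound 1 within the scatter. Compound 3 shows a higher number than compound 2 , and that gap lies beyond the scatter.

The change to follow is a group of 4 heavy atoms (1 nitrogen, 2 oxygen, 1 sulfur; no ring) in place of a group of 2 heavy atoms (1 carbon, 1 nitrogen; no ring), on an aromatic carbon. In words, a group of 4 heavy atoms (1 nitrogen, 2 oxygen, 1 sulfur; no ring) goes in place of a group of 2 heavy atoms (1 carbon, 1 nitrogen; no ring), on an aromatic carbon.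

For the measured compounds named here, one measured step bears on this, where a group of 2 heavy atoms replaces a hydrogen atom on an aromatic carbon: a 1.6-fold higher number from compound 1 to compound 2 (0.20 log units; within the scatter). That step is small and stays within the scatter. Going by the values given here, compound 3 differs from the others in more than one place and gives no clean step. Among the compounds with values here, no measured compound carries the sulfamoyl group, so the evidence is thin and the range is kept wide.

No step beyond the scatter is expected in this assay, and no direction can be argued from the data. The estimate amounts to a 1.3-fold lower number from compound 2 to compound 4 (0.10 log units; within the scatter), an expected step within the scatter. For compound 4 the expected value is 6300 nM, with an estimated range from 2500 nM to 16000 nM.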

Compound 4, half-maximal inhibitory concentration: 20000 nM
Estimate against measurement, compound 4: 3.2-fold (0.50 log units) below; the whole stated range lies below it.
By their numbers in this assay, from the lowest: compounds 1 and 2 (each within the scatter of the next); then compounds 3 and 4 (each within the scatter of the next).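

In this assay, this place on the aromatic carbon now proves sensitive to the group it carries, which the earlier step, a 1.6-fold higher number from compound 1 to compound 2 (0.20 log units; within the scatter), did not show. Sulfamoyl gives a 4.0-fold higher number from compound 1 to compound 4 (0.60 log units; beyond the scatter) when it replaces hydrogen and a 2.5-fold higher number from compound 2 to compound 4 (0.40 log units; beyond the scatter) when it replaces the group of 2 heavy atoms; both steps lie beyond the scatter, though both are modest, so the tolerance seen with the smaller group does not extend to every group at this place. Nothing at hand accounts for the difference between the two groups.

On these data alone, it remains open whether the higher number belongs to sulfamoyl alone or would also appear with a carboxylic acid, an amine or a methylsulfonyl group at the same carbon, since the series holds only hydrogen, the group of 2 heavy atoms and sulfamoyl there alongside the rest of the shared core. As far as these compounds go, it is equally open whether a longer chain in place of the ethyl end of the shared core would change the size of the sulfamoyl step.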